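Amino in place of fluoro: estimating compound 4

The source may report more compounds than this note shows. Statements on the series, on what has been measured and on what is new or still open speak of the compounds shown alone.

Measured in a functional assay on T-24 cells (Homo sapiens) for cytotoxicity, read by MTT assay, with a stated time of 48 h; a higher number here means a weaker inhibitor, a lower number a stronger inhibitor:
- compound 1 `COc1cc(C(=O)c2cn(-c3cccc(N)c3)cc2-c2ccccc2[N+](=O)[O-])cc(OC)c1OC`: 12 nM
- compound 2 `COc1cc(C(=O)c2cn(-c3cccc(N)c3)cc2-c2ccc(N)cc2)cc(OC)c1OC`: 12 nM
- compound 3 `COc1cc(C(=O)c2cn(-c3ccc(F)cc3)cc2-c2ccc(N)cc2)cc(OC)c1OC`: 48 nM

Compound 3 has the highest number of the three. Compound 4 `COc1cc(C(=O)c2cn(-c3ccc(N)cc3)cc2-c2ccc(N)cc2)cc(OC)c1OC` differs from it by amino in place of fluoro on an aromatic carbon. The closest evidence is a 4.0-fold higher number from compound 2 to compound 3 (0.60 log units; beyond the scatter), where 4-fluorophenyl replaced an aminophenyl on the aromatic nitrogen. Compound 4 puts an amino group back on that ring, but not where compound 2 at 12 nM carries it, so perhaps only part of that step returns. The other step, no change at the digits printed from compound 1 to compound 2 (within the scatter), changes a different group and says little here. A modestly lower number is therefore expected, and the expected change is a 2.4-fold lower number from compound 3 to compound 4 (0.38 log units; beyond the scatter). Compound 4 is estimated at 20 nM, with an expected range of 7 nM to 60 nM.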

Compound 4, half-maximal inhibitory concentration: 58 nM
The estimate for compound 4 lay 2.9-fold (0.46 log units) below the measured number, and the stated range covers the measured number.
By their numbers in this assay, from the lowest: compounds 1 and 2 (each within the scatter of the next); then compounds 3 and 4 (each within the scatter of the next).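

In this assay fluoro and amino cannot be told apart when they sit para to a large group on this ring, giving a 1.2-fold higher number from compound 3 to compound 4 (0.08 log units; within the scatter). The place of the amino group matters more than its presence, as 4-aminophenyl in place of 3-aminophenyl gives a 4.8-fold higher number from compound 2 to compound 4 (0.68 log units; beyond the scatter). Nothing available explains this difference.

Still open, as far as these compounds go, is whether 3-fluorophenyl on the nitrogen would match 3-aminophenyl, which would separate the role of place from that of the group. From the compounds shown here alone, a carboxylic acid or methoxy group at either place also remains untested here.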